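A few compounds are considered here, and "the series" means these few. Any claim that something is new, unique, unknown or untested is made for them only; others in the source may bear on it.

Compound 1 `CC(C)C(=O)N1CCc2cc(CNC(=O)c3cccs3)ccc21` gives 100% in an assay on HEK293 cells for inhibition of Indoleamine 2,3-dioxygenase 1 (Homo sapiens), tested at 10 uM (a higher number here means more inhibition at the concentration tested (going by the name of the read-out), a lower number less inhibition), and compound 2 `CC(=O)N1CCc2cc(CNC(=O)c3cccs3)ccc21` gives 72%, the lowest of the two numbers. The step of a number 28 percentage points lower from compound 1 to compound 2 (beyond the scatter) is the only one measured. Compound 3 `CC(C)CC(=O)N1CCc2cc(CNC(=O)c3cccs3)ccc21` differs from compound 2 by isopropyl in place of hydrogen on a saturated chain carbon bound to a carbonyl carbon. Since the acyl group on the shared core grows in this step, as it did going back toward compound 1, the inhibition of compound 3 is expected to rise again by about a number 18 percentage points higher from compound 2 to compound 3 (beyond the scatter), though not beyond what compound 1 shows. Compound 3 is therefore estimated at 90%, in the range 70% to 100%.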

Compound 3, a percentage reported as inhibition, at one concentration (the size of the read-out at that concentration, not a potency): 100%
Compound 3: the middle estimate sits 10 percentage points below what was measured; the range from low to high includes it.
By their numbers in this assay, from the lowest: compound 2; then compounds 1 and 3 (each within the scatter of the next).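

In this assay, isopropyl in place of hydrogen on the saturated chain carbon bound to the carbonyl carbon gives a clear gain over the acetyl amide (a number 28 percentage points higher from compound 2 to compound 3 (beyond the scatter)). The isobutyl and isopropyl groups on the carbonyl carbon are not told apart here (no change at the digits printed from compound 1 to compound 3 (within the scatter)), so two different acyl groups larger than acetyl read alike at this position. No evidence on why the acyl group matters is available.

On these data alone, whether a longer chain, a cyclohexyl group or an amine on this acyl chain would read the same remains open. A single-concentration percentage also gives no potency ranking of compound 1 and compound 3.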